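Urea series: chloro for trifluoromethyl on the methoxy analogue

The source may report more compounds than this note shows. Statements on the series, on what has been measured and on what is new or still open speak of the compounds shown alone.

Measured so far in a functional assay on SR cells (Homo sapiens) for inhibition, read by sulforhodamine B assay, with a stated time of 48 h, tested at 0.1 uM; a higher number here means a weaker effect of the compound at the concentration tested, a lower number a stronger effect:
compound 1, `O=C(Nc1cccc(-n2cc(-c3ccncc3)c(-c3cc(O)cc(Cl)c3)n2)c1)Nc1ccc(Cl)c(C(F)(F)F)c1`, gives 98%.
compound 2, `O=C(Nc1cccc(-n2cc(-c3ccncc3)c(-c3cc(O)cc(Cl)c3)n2)c1)Nc1ccc(Cl)c(Cl)c1`, gives 90%.
compound 3, `COc1cc(Cl)cc(-c2nn(-c3cccc(NC(=O)Nc4ccc(Cl)c(C(F)(F)F)c4)c3)cc2-c2ccncc2)c1`, gives 92%.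

Compound 3 stands second highest of the three numbers; compound 2 lies nearest to it and compound 1 furthest, both within the scatter. Compound 4, `COc1cc(Cl)cc(-c2nn(-c3cccc(NC(=O)Nc4ccc(Cl)c(Cl)c4)c3)cc2-c2ccncc2)c1`, differs from compound 3 in one place: chloro in place of trifluoromethyl on an aromatic carbon. The same change has been measured once, between compound 1 and compound 2, where it gave a number 8 percentage points lower from compound 1 to compound 2 (within the scatter). The other measured step, a number 6 percentage points lower from compound 1 to compound 3 (within the scatter), is the methyl-for-hydrogen change that separates compound 3 from compound 1 and serves only as context here. A step of about the same small size, downward but not beyond the scatter, is therefore expected in this assay, namely a number 6 percentage points lower from compound 3 to compound 4 (within the scatter). Compound 4 is estimated at 86%, between 72% and 98%.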

Compound 4, a percentage reported as activity, at one concentration (the size of the read-out at that concentration, not a potency): 51%
Compound 4: middle estimate off by 35 percentage points, on the high side; the whole stated range lies above it.
By their numbers in this assay, from the lowest: compound 4; then compounds 2, 3 and 1 (each within the scatter of the next).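

In this assay, chloro in place of trifluoromethyl at this position gives a number 41 percentage points lower from compound 3 to compound 4 (beyond the scatter) on the methoxy core, so the size of the change depends on the core that carries it: the same change on two cores in this assay, a number 8 percentage points lower (within the scatter) from compound 1 to compound 2 and a number 41 percentage points lower (beyond the scatter) from compound 3 to compound 4, 33 percentage points apart, beyond the scatter of two such steps
Likewise, the methyl in place of hydrogen on the oxygen gives a number 39 percentage points lower from compound 2 to compound 4 (beyond the scatter) with the 3,4-dichlorophenyl group in place, so that change depends on the group at the far end of the urea: the same change on two cores in this assay, a number 6 percentage points lower (within the scatter) from compound 1 to compound 3 and a number 39 percentage points lower (beyond the scatter) from compound 2 to compound 4, 33 percentage points apart, beyond the scatter of two such steps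
The two changes therefore do not add up across these four compounds.

As far as these compounds go, whether a nitrile or a methyl at this position would behave like chloro remains open. So does the outcome with an amine in place of the methoxy group.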